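This account rests on a few compounds, and the source may have more. Where it says the series, first, only, none or still open, it means among the compounds named here.

Compound 1 `Fc1cc(Cl)ccc1-c1ccc(Cn2nnc3ccccc32)cn1` is the compound from which this step is taken. In a functional assay on cells for positive allosteric modulation of metabotropic glutamate receptor 2 (Homo sapiens), read by fluorescence and calcium flux, with a stated time of 30 min (a higher number here means that more compound is needed for the effect, a lower number that less compound is needed), compound 1 gives 50 nM, the lowest of the two numbers recorded so far. Its nearest neighbour is compound 2 `Fc1ccc2c(c1)nnn2Cc1ccc(-c2ccc(Cl)cc2F)nc1`, which in this assay gives 68 nM; the step of a 1.4-fold higher number from compound 1 to compound 2 (0.13 log units; within the scatter) lies within the scatter of the measurement, so the two compounds cannot be separated on this evidence.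

Compound 3 `Fc1cc(Cl)ccc1-c1ccc(Cn2nnc3c(C(F)(F)F)cccc32)cn1` differs from compound 1 by trifluoromethyl in place of hydrogen on an aromatic carbon. Among the measured compounds shown here, the only measured step available, a 1.4-fold higher number from compound 1 to compound 2 (0.13 log units; within the scatter), also concerns a small substituent entering in place of hydrogen on the shared core of compound 1, and it produced no change beyond the scatter. For the measured compounds named here, no measured step concerns a trifluoromethyl group, and no measured step concerns the position in which it now enters, so the comparison is indirect. On that basis compound 3 is expected to stay close to compound 1, with a step of about a 1.4-fold higher number from compound 1 to compound 3 (0.15 log units; within the scatter) that is not expected to rise beyond the scatter. The estimate for compound 3 in this assay is therefore 70 nM, with a range from 25 nM to 200 nM.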

Compound 3, half-maximal effective concentration: 13 nM
Compound 3: the middle estimate sits 5.4-fold (0.73 log units) above what was measured; the whole stated range lies above it.
By their numbers in this assay, from the lowest: compound 3; then compounds 1 and 2 (each within the scatter of the next).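

Among the compounds shown here, at this place, on an aromatic carbon of a six-membered aromatic ring of carbon only, part of a fused or bridged system of two rings, ortho to a fused ring, the shared core is sensitive to substitution: in this assay trifluoromethyl in place of hydrogen gives a 3.8-fold lower number from compound 1 to compound 3 (0.59 log units; beyond the scatter) and is the first step here beyond the scatter, though a modest one. For the compounds shown here, the only earlier step, with fluoro in place of hydrogen, gave a 1.4-fold higher number from compound 1 to compound 2 (0.13 log units; within the scatter) and so showed no such change, but these two steps differ both in the group that enters and in the carbon that carries it. There is no evidence here that accounts for the lower number of compound 3.

The compounds shown leave open whether this lower number belongs to trifluoromethyl itself or would follow from other groups at this place. A fluoro group, a methyl group, a nitrile or an amine on this same carbon would help to separate these two readings.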